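A few compounds are considered here, and "the series" means these few. Any claim that something is new, unique, unknown or untested is made for them only; others in the source may bear on it.

Measured compounds in an ADME assay on cells (Homo sapiens) for cytotoxicity, read by polymerase chain reaction, with a stated time of 3 days; a higher number here means that more compound is tolerated, a lower number that less compound is tolerated:
Compound 1, `CNc1nc(C)c(-c2nc3ccccc3s2)c(N[C@@H]2C[C@H](CO)[C@@H](O)[C@H]2O)n1`, sits at a limit: > 25000 nM.
Compound 2, `CCCNc1nc(C)c(-c2nc3ccccc3s2)c(N[C@@H]2C[C@H](CO)[C@@H](O)[C@H]2O)n1`, sits at a limit: > 25000 nM.
Compound 3, `Cc1nc(NC(C)C)nc(N[C@@H]2C[C@H](CO)[C@@H](O)[C@H]2O)c1-c1nc2ccccc2s1`, gives 13000 nM.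

Within the data shown here, compound 3 therefore holds the only number in this assay; the other two values are limits, as the limit of > 25000 nM in this assay, at which 2 of the 3 values shown sit, records. The step from compound 1 to compound 2 is left unreadable by the two limits a step that the two limits leave unreadable from compound 1 to compound 2. The steps that end at compound 3 are an at least 1.9-fold lower number from compound 1 to compound 3 (0.28 log units; that floor lies within the scatter) and an at least 1.9-fold lower number from compound 2 to compound 3 (0.28 log units; that floor lies within the scatter), each a floor within the scatter.

Compound 4, `Cc1nc(NCC2CC2)nc(N[C@@H]2C[C@H](CO)[C@@H](O)[C@H]2O)c1-c1nc2ccccc2s1`, differs from compound 3 by cyclopropylmethyl in place of isopropyl on a nitrogen on an aromatic ring. The alkyl changes around this nitrogen so far give no step beyond the scatter, so no step beyond the scatter is expected here either, a 1.2-fold higher number from compound 3 to compound 4 (0.06 log units; within the scatter). Compound 4 is estimated at 15000 nM, from 7000 nM to 30000 nM.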

Compound 4, half-maximal cytotoxic concentration: 8000 nM
Estimate against measurement, compound 4: 1.9-fold (0.27 log units) above; measured number inside the range.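

In this assay, cyclopropylmethyl in place of isopropyl on this nitrogen gives a 1.6-fold lower number from compound 3 to compound 4 (0.21 log units; within the scatter), so these two groups remain unseparated. Among these compounds, measured against the other two compounds, the same cyclopropylmethyl group gives an at least 3.1-fold lower number from compound 2 to compound 4 (0.49 log units; beyond the scatter) and an at least 3.1-fold lower number from compound 1 to compound 4 (0.49 log units; beyond the scatter), the first steps at this nitrogen printed beyond the scatter. Compound 1 and compound 2 each sit at a limit, so both steps are floors: the limit of > 25000 nM in this assay, at which 2 of the 4 values shown sit.

On these data alone, the true size of those two steps stays open. Also open, as far as these compounds go, is whether a cyclobutylmethyl group, a longer chain or a chain carrying an amine on this nitrogen would track compound 4.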